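A second acid on the amide nitrogen

The source may hold more compounds than are shown below. What is called first, only, known or untested is meant among the compounds shown, and "the series" means these compounds.

Going by the values given here, in a functional assay on MCF7 cells (Homo sapiens) for antiproliferative activity, read by MTT assay, with a stated time of 24 h (a lower number here means a stronger inhibitor, a higher number a weaker inhibitor), compound 1 `CCn1c(C(=O)N[C@H](CO)CCO)ccc1C(CC)(CC)c1ccc(OCS(=O)(=O)c2ccccc2)c(C)c1` gives 28500 nM and compound 2 `CCn1c(C(=O)NC2(C(=O)O)CC2)ccc1C(CC)(CC)c1ccc(OCS(=O)(=O)c2ccccc2)c(C)c1` gives 41200 nM so compound 2 stands level with its only measured neighbour. Among the compounds with values here, the step between them, 1-carboxycyclopropyl in place of 3-hydroxy-1-(hydroxymethyl)propyl on an amide-type nitrogen, is a 1.4-fold higher number from compound 1 to compound 2 (0.16 log units; within the scatter) and it is the only measured step that bears on what follows. Compound 3 `CCn1c(C(=O)N[C@@H](CC(=O)O)C(=O)O)ccc1C(CC)(CC)c1ccc(OCS(=O)(=O)c2ccccc2)c(C)c1` changes that same nitrogen substituent again: 1,2-dicarboxyethyl in place of 1-carboxycyclopropyl on an amide-type nitrogen in words, 1,2-dicarboxyethyl in place of 1-carboxycyclopropyl on an amide-type nitrogen. Within the data shown here, one step is thin evidence, and no measured compound yet carries the entering group. The earlier exchange at this nitrogen stayed within the scatter, so no change beyond the scatter is expected here, and the estimate means a 1.1-fold higher number from compound 2 to compound 3 (0.04 log units; within the scatter) in either direction. Compound 3 is expected at 45000 nM in this assay (estimated range 20000 nM to 100000 nM).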

Compound 3, half-maximal inhibitory concentration: > 50000 nM
Compound 3: a limit, no number; the forecaster's own chance of this, stated with the estimate: 15%; at least 1.1-fold (0.04 log units) between middle value and limit.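

Of the three compounds, only compound 3 reads as a limit and not as a number in this assay: the limit of > 50000 nM in this assay, at which 1 of the 3 values shown sits. At this amide-type nitrogen, the entry of 1,2-dicarboxyethyl gives an at least 1.2-fold higher number from compound 2 to compound 3 (0.08 log units; that floor lies within the scatter), and the same group gives an at least 1.7-fold higher number from compound 1 to compound 3 (0.24 log units; that floor lies within the scatter). Both figures are floors and not sizes, so the result does not separate 1,2-dicarboxyethyl from either 1-carboxycyclopropyl or 3-hydroxy-1-(hydroxymethyl)propyl, although it adds a substituent with two carboxylic acids to the exchanges seen at this nitrogen.

Going by these compounds, the true size of both steps stays open. So does whether an amine, or a longer chain ending in a single carboxylic acid, on this nitrogen would give a number in this assay.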